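Adding a nitrophenyl group to a weak ovarian-cell inhibitor

This account rests on a few compounds, and the source may have more. Where it says the series, first, only, none or still open, it means among the compounds named here.

Measured compounds:
- compound 1, `COc1ccc(OCCOCCNC2CCCC2)cc1`: 99100 nM
- compound 2, `c1ccc(COc2ccc(OCCOCCNc3ccccc3)cc2)cc1`: > 100000 nM
- compound 3, `c1ccc(COc2ccc(OCCOCCNC3CC3)cc2)cc1`: 47200 nM

In a functional assay on SK-OV-3 cells (Homo sapiens) for inhibition, read by CCK-8 assay, with a stated time of 70 h (on this read-out higher numbers stand for weaker inhibition and lower numbers for stronger inhibition), compound 1 gives 99100 nM, the highest of the two numbers shown; the next number, from compound 3, lies lower and beyond the scatter. For compound 2 the result is only a limit of the assay, (the limit of > 100000 nM in this assay, at which 1 of the 3 values shown sits). Among the measured compounds shown here, the one measured step, an at least 2.1-fold lower number from compound 2 to compound 3 (0.32 log units; beyond the scatter), concerns the amine nitrogen, not the place changed here.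

Compound 4, `O=[N+]([O-])c1ccccc1COc1ccc(OCCOCCNC2CCCC2)cc1`, differs from compound 1 as 2-nitrophenyl in place of hydrogen on a saturated chain carbon bound to an oxygen on an aromatic ring. For the measured compounds named here, no measured step bears on this change, so only a small shift in this assay is expected, a 1.7-fold lower number from compound 1 to compound 4 (0.22 log units; within the scatter). Compound 4 is estimated at 60000 nM, between 20000 nM and 150000 nM.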

Compound 4, half-maximal inhibitory concentration: 5370 nM
Compound 4: middle estimate off by 11-fold (1.05 log units), on the high side, and the stated range ends above it.
By their numbers in this assay, from the lowest: compound 4; then compound 3; then compound 1. At a limit, above all of these: compound 2.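

In this assay, putting 2-nitrophenyl in place of hydrogen gives an 18-fold lower number from compound 1 to compound 4 (1.27 log units; beyond the scatter), a large step. Among the compounds shown here, the earlier step concerned only the amine nitrogen, so this is the first sign that the saturated chain carbon bound to an oxygen on an aromatic ring is also a place where a change counts. Nothing measured here explains why this group has such an effect. From the compounds shown here alone, it remains open whether the nitro group or the aromatic ring carrying it accounts for the change, and whether plain phenyl, or an amine or carboxylic acid in place of the nitro group, would do the same.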